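Swapping chloro for fluoro on the phenoxy arm

This account rests on a few compounds, and the source may have more. Where it says the series, first, only, none or still open, it means among the compounds named here.

The measured compounds:
compound 1, `Nc1nc(N2CCN(C(=O)COc3ccc(Cl)cc3)CC2)c2nc(-c3ccc(F)cc3)sc2n1`: 490 nM
compound 2, `CC(C)(Oc1ccc(Cl)cc1)C(=O)N1CCN(c2nc(N)nc3sc(-c4ccc(F)cc4)nc23)CC1`: > 10000 nM
compound 3, `Nc1nc(N2CCN(C(=O)OCc3ccccc3)CC2)c2nc(-c3ccc(F)cc3)sc2n1`: 4900 nM

In a functional assay on cells (Lymphocyte, Homo sapiens) (a higher number here means a weaker inhibitor, a lower number a stronger inhibitor), compound 1 gives 490 nM, the lowest of the two numbers shown. Compound 2 gives no number here but only a limit, > 10000 nM, so an at least 20-fold higher number from compound 1 to compound 2 (1.30 log units; beyond the scatter) is known only as a floor (the limit of > 10000 nM in this assay, at which 1 of the 3 values shown sits). Compound 3 reads a 10-fold higher number from compound 1 to compound 3 (1.00 log units; beyond the scatter). Both changes rework the group on the carbonyl carbon as a whole. The unmeasured compound 4, `Nc1nc(N2CCN(C(=O)COc3ccc(F)cc3)CC2)c2nc(-c3ccc(F)cc3)sc2n1`, is different: it keeps that group and alters only one atom, (fluoro in place of chloro on an aromatic carbon), read more broadly as (4-chlorophenoxy)methyl to (4-fluorophenoxy)methyl. Among the compounds with values here, no measured step touches that position, so neither the loss to compound 2 nor the loss to compound 3 speaks directly to it. A step near the scatter is therefore expected, with a slight lean toward a higher number. Compound 4 is expected to give 800 nM, in the range 300 nM to 2500 nM. This estimate means an expected step of a 1.6-fold higher number from compound 1 to compound 4 (0.21 log units; within the scatter).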

Compound 4, half-maximal inhibitory concentration: 70 nM
Estimate against measurement, compound 4: 11-fold (1.06 log units) above; measured number below the stated range.
By their numbers in this assay, from the lowest: compound 4; then compound 1; then compound 3. At a limit, above all of these: compound 2.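

Fluoro in place of chloro on the phenoxy arm gives a 7.0-fold lower number from compound 1 to compound 4 (0.85 log units; beyond the scatter), so in this assay this single atom, which no earlier step touched, has a clear effect on the reading. The (4-fluorophenoxy)methyl group also stands much further from benzyloxy than the (4-chlorophenoxy)methyl group did, with a 70-fold lower number from compound 3 to compound 4 (1.85 log units; beyond the scatter). Compound 2 carries only a limit, so an at least 140-fold lower number from compound 2 to compound 4 (2.15 log units; beyond the scatter) is a floor and not a measured size: the limit of > 10000 nM in this assay, at which 1 of the 4 values shown sits.

The compounds shown leave open how a hydrogen, a methyl or a nitrile would read on this aromatic carbon, and so whether fluoro is especially favourable or chloro especially poor here. They also leave open whether fluoro in place of chloro on the arm of compound 2 would lift it clear of its limit.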